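The source may hold more compounds than are shown below. What is called first, only, known or untested is meant among the compounds shown, and "the series" means these compounds.

Measured so far in a functional assay on HOS-TE85 cells (Homo sapiens) for inhibition, read by CCK-8 assay, with a stated time of 72 h; on this read-out lower numbers stand for stronger inhibition and higher numbers for weaker inhibition

compound 1 (`CC1SC(c2cccc(C(=O)NCCCCc3ccccc3)c2)N(c2ccc(C3CC3)cc2)C1=O`) 191 nM
compound 2 (`CC1SC(c2cccc(C(=O)NCCCCc3ccccc3)c2)N(c2cccc(C3CC3)c2)C1=O`) 295 nM

For the measured compounds named here, compound 2 lies within the scatter of compound 1, the only other measured compound, so these two numbers cannot be ranked (a 1.5-fold higher number from compound 1 to compound 2 (0.19 log units; within the scatter)). Compound 3 (`CCOc1ccccc1N1C(=O)C(C)SC1c1cccc(C(=O)NCCCCc2ccccc2)c1`) has not yet been measured. Its difference from compound 2 is as follows: 2-ethoxyphenyl in place of 3-cyclopropylphenyl on an amide-type nitrogen in a ring In words, this is 2-ethoxyphenyl in place of 3-cyclopropylphenyl on an amide-type nitrogen in a ring.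

Going by the values given here, only one measured step bears on this change: the earlier swap at the same place, 3-cyclopropylphenyl in place of 4-cyclopropylphenyl, which stayed within the scatter. Among the compounds with values here, that is thin support, since no measured compound carries 2-ethoxyphenyl and the new group differs in kind, not only in placement. The data therefore give no direction, and no step beyond the scatter is expected in this assay, although the range has to stay wide. The expected step is a 1.0-fold higher number from compound 2 to compound 3 (0.01 log units; within the scatter) and remains an estimate only. Compound 3 is estimated at 300 nM with an expected range of 110 nM to 850 nM for the measurement.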

Compound 3, half-maximal inhibitory concentration: 71.6 nM
Beside the measured number, compound 3's estimate is 4.2-fold (0.62 log units) above it, outside the stated range (below it).
By their numbers in this assay, from the lowest: compound 3; then compounds 1 and 2 (each within the scatter of the next).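

In this assay, replacing either cyclopropylphenyl group on the amide-type nitrogen with 2-ethoxyphenyl gives a step beyond the scatter: a 4.1-fold lower number from compound 2 to compound 3 (0.61 log units; beyond the scatter), and a 2.7-fold lower number from compound 1 to compound 3 (0.43 log units; beyond the scatter). The earlier swap between the two cyclopropylphenyl groups gave only a 1.5-fold higher number from compound 1 to compound 2 (0.19 log units; within the scatter), so this position had shown no readable response until now, and compound 3 is the only one of the three separated from both others. Nothing in hand accounts for the stronger inhibition seen with 2-ethoxyphenyl.

This change removes the three-membered ring, brings in an oxygen and a hydrogen-bond acceptor, and alters the placement of the substituent all at once, so the compounds shown cannot assign the step to any one of these differences. Open comparisons at this position are 2-cyclopropylphenyl, which would keep the placement and the three-membered ring, and 4-ethoxyphenyl or 2-methoxyphenyl, which would test the placement and the length of the chain on the oxygen.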